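This account rests on a few compounds, and the source may have more. Where it says the series, first, only, none or still open, it means among the compounds named here.

Measured compounds in a functional assay on HCC1806 cells (Homo sapiens) for inhibition, read by sulforhodamine B assay, tested at 10 uM; a higher number here means more inhibition at the concentration tested (going by the name of the read-out), a lower number less inhibition:
compound 1 `CN(C)c1ccc(C2CC(c3ccc(-n4cncn4)cc3)=NN2C(=O)c2ccc(F)cc2)cc1` with 15.6%
compound 2 `CN(C)c1ccc(C2CC(c3ccc(-n4cncn4)cc3)=NN2C(=O)c2cc(Cl)cc(Cl)c2)cc1` with 5.3%
compound 3 `CN(C)c1ccc(C2CC(c3ccc(-n4ccnc4)cc3)=NN2C(=O)c2ccc(F)cc2)cc1` with 7.1%

The change 3,5-dichlorophenyl in place of 4-fluorophenyl on a carbonyl carbon produced a number 10.3 percentage points lower from compound 1 to compound 2 (beyond the scatter). The two cores differ by 1H-imidazol-1-yl in place of 1H-1,2,4-triazol-1-yl on an aromatic carbon, and that change produced a number 8.5 percentage points lower from compound 1 to compound 3 (within the scatter). Compound 4 `CN(C)c1ccc(C2CC(c3ccc(-n4ccnc4)cc3)=NN2C(=O)c2cc(Cl)cc(Cl)c2)cc1` remains unmeasured. Among the compounds with values here, it carries, relative to compound 3, the change (3,5-dichlorophenyl in place of 4-fluorophenyl on a carbonyl carbon), which is the same change as the one made from compound 1 to compound 2, at the same place. Within the data shown here, for compound 4 a step of about the earlier size is expected, a number 7.1 percentage points lower from compound 3 to compound 4 (within the scatter), because the one precedent in this assay showed a number 10.3 percentage points lower from compound 1 to compound 2 (beyond the scatter). This rests on a single step and on compound 3 with its value of 7.1% as starting point, so the estimate is loosely bounded. Compound 4 is expected to give 0% in this assay. For compound 4 the expected range runs from -10% to 10%.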

Compound 4, a percentage reported as inhibition, at one concentration (the size of the read-out at that concentration, not a potency): 44.5%
Compound 4: the middle estimate sits 44.5 percentage points below what was measured; the whole stated range lies below it.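

In this assay, 3,5-dichlorophenyl in place of 4-fluorophenyl on the carbonyl carbon gives a number 37.4 percentage points higher from compound 3 to compound 4 (beyond the scatter), so this change does not carry from one core to the other: the same change on two cores in this assay, a number 10.3 percentage points lower (beyond the scatter) from compound 1 to compound 2 and a number 37.4 percentage points higher (beyond the scatter) from compound 3 to compound 4, 47.7 percentage points apart, beyond the scatter of two such steps. Read the other way, 1H-imidazol-1-yl in place of 1H-1,2,4-triazol-1-yl gives a number 39.2 percentage points higher from compound 2 to compound 4 (beyond the scatter), so that change also depends on its partner group: the same change on two cores in this assay, a number 8.5 percentage points lower (within the scatter) from compound 1 to compound 3 and a number 39.2 percentage points higher (beyond the scatter) from compound 2 to compound 4, 47.7 percentage points apart, beyond the scatter of two such steps. This shows that the two changes do not act independently in this set of four compounds, but it rests on a single pair of cores at one concentration and does not show why they interact or how potency differs.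

On these data alone, it remains open whether the high reading needs 3,5-dichlorophenyl specifically on the imidazole core. A pyridyl or cyclohexyl group on the carbonyl carbon would test how far the result extends beyond these two aryl groups.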